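A few compounds are considered here, and "the series" means these few. Any claim that something is new, unique, unknown or untested is made for them only; others in the source may bear on it.

Measured compounds:
compound 1 `O=C(O)[C@H]1C[C@@H]1c1ccc(NCc2cccc(Oc3ccccc3)c2)cc1`; compound 2 `O=C(O)[C@@H]1C[C@H]1c1ccc(NCc2cccc(Oc3ccccc3)c2)cc1`.

In a functional assay on CHO cells for agonist activity at Free fatty acid receptor 1 (Homo sapiens) (on this read-out lower numbers stand for an effect already at smaller amounts and higher numbers for an effect only at larger amounts of compound), compound 1 gives 12.3 nM; 13.5 nM (2 entries) (the several entries of compound 1 in this assay, 12.3 nM; 13.5 nM (2 entries)). In this assay compound 2 gives 562 nM; compound 2 has one further entry without a single number, and on the numbers shown it stands as the weaker of the two stereoisomers (the fact that compounds 1 and 2 differ only in the configuration as drawn).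

Compound 3 `CC(C)NC(=O)[C@H]1C[C@@H]1c1ccc(NCc2cccc(Oc3ccccc3)c2)cc1` is not yet measured. It differs from compound 2 by 2-(isopropylcarbamoyl)cyclopropyl in place of 2-carboxycyclopropyl on an aromatic carbon. Going by the values given here, no measured step of this kind exists. Compound 3 is expected to be markedly weaker, with a 27-fold higher number from compound 2 to compound 3 (1.43 log units; beyond the scatter) estimated as a step well beyond the scatter. The estimate for compound 3 in this assay is 15000 nM, within 2000 nM to 100000 nM.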

Compound 3, half-maximal effective concentration: 12.6 nM
Compound 3: middle estimate off by 1200-fold (3.08 log units), on the high side; the whole stated range lies above it.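

At this position, para to a large group, 2-(isopropylcarbamoyl)cyclopropyl is well accepted in this assay, with a 45-fold lower number from compound 2 to compound 3 (1.65 log units; beyond the scatter). A carboxylic acid is therefore not needed here for a low number: compound 1 gives 12.3 nM; 13.5 nM (2 entries) and compound 3 gives 12.6 nM. Compound 3 is drawn with the configuration of compound 1, so this step joins the group change to a change of configuration, which alone separates the two acids: the fact that compounds 1 and 2 differ only in the configuration as drawn

Open, on these data alone, is how the isopropyl amide behaves in the opposite configuration. Also open, as far as these compounds go, is whether a primary carboxamide or an aminomethyl group at this place gives a similar number.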